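Trifluoromethyl on the phenyl of compound 3

The source may hold more compounds than are shown below. What is called first, only, known or untested is meant among the compounds shown, and "the series" means these compounds.

Compound 3 `O=C(O)C[C@H](O)C[C@H](O)CCn1c(C(F)(F)F)nc(-c2ccc(F)cc2)c1-c1ccccc1` gives 201 nM in an assay on microsomes from liver for inhibition of 3-hydroxy-3-methylglutaryl-coenzyme A reductase (Rattus norvegicus) (on this read-out lower numbers stand for stronger inhibition and higher numbers for weaker inhibition), and stands highest of the three numbers measured in the series. Compound 1 `O=C(O)C[C@H](O)C[C@H](O)CCn1c(C(F)(F)F)nc(-c2ccccc2)c1-c1ccc(F)cc1` gives 31 nM, and compound 2 `COc1cccc(-c2nc(C(F)(F)F)n(CC[C@@H](O)C[C@@H](O)CC(=O)O)c2-c2ccc(F)cc2)c1` gives 20 nM; both lie beyond the scatter from compound 3, compound 2 furthest. Compound 4 `O=C(O)C[C@H](O)C[C@H](O)CCn1c(C(F)(F)F)nc(-c2ccc(F)cc2)c1-c1ccc(C(F)(F)F)cc1` is the next member to be measured in this assay. It differs from compound 3 in one place: trifluoromethyl in place of hydrogen on an aromatic carbon.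

Among the compounds with values here, only one measured step involves a substituent entering an aromatic carbon of the shared core. That step is a 1.6-fold lower number from compound 1 to compound 2 (0.19 log units; within the scatter), a change that stayed within the scatter. Within the data shown here, no measured pair shows a trifluoromethyl entering a phenyl ring, so the step from compound 3 to compound 4 has no direct precedent. Because a 1.6-fold lower number from compound 1 to compound 2 (0.19 log units; within the scatter) did not move the number beyond the scatter, the expectation for compound 4 in this assay is a step of about a 1.1-fold lower number from compound 3 to compound 4 (0.05 log units; within the scatter), that is no change beyond the scatter in either direction. Compound 4 is therefore estimated at 180 nM in this assay, with a range from 60 nM to 550 nM.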

Compound 4, half-maximal inhibitory concentration: > 1000 nM
Compound 4 gave a limit, no number (the forecaster's own chance of this, stated with the estimate: 2%); middle value at least 5.5-fold (0.74 log units) away from the limit.
By their numbers in this assay, from the lowest: compounds 2 and 1 (each within the scatter of the next); then compound 3. At a limit, above all of these: compound 4.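

Compound 4 reads > 1000 nM in this assay, which is a limit of the assay and not a number. Within the data shown here, the step, an at least 4.9-fold higher number from compound 3 to compound 4 (0.69 log units; beyond the scatter), shows that this aromatic carbon of the phenyl in compound 3 is sensitive to substitution: trifluoromethyl there weakens inhibition beyond the scatter, which the only earlier substituent step, on another aromatic ring of the shared core, did not show with a 1.6-fold lower number from compound 1 to compound 2 (0.19 log units; within the scatter). The true size of the step remains unknown, so the series fixes only its direction and a minimum, with the top of the range resting on a limit: the limit of > 1000 nM in this assay, at which 1 of the 4 values shown sits.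

Still open, going by these compounds, is whether the weakening belongs to trifluoromethyl itself or to any substituent on this carbon, a question that a methyl, a chlorine, a hydroxyl or an amine at the same place would address. Also open, on these data alone, is whether trifluoromethyl on the other aromatic ring of the shared core would carry the same penalty, or whether this carbon is unusual among the aromatic positions of the series.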